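The compounds below may be only part of what the source reports. "The series", "measured", "known", "first", "only" and "open" are said of these compounds alone.

Working notes on the series, read in a functional assay on Vero cells (Chlorocebus sabaeus) for inhibition; a higher number here means a weaker inhibitor, a lower number a stronger inhibitor. Compound 1 (`COc1cc(/C=C/C(=O)c2cccc(NC(=O)c3cccs3)c2)ccc1O`) gives 3.98 ug/mL, and compound 2 (`COc1cc(/C=C/C(=O)c2cccc(NC(=O)c3ccco3)c2)ccc1O`) gives 3.11 ug/mL. Among the compounds with values here, compound 2 therefore lies within the scatter of compound 1, the only other measured compound, and the pair cannot be ranked. Next comes compound 3 (`COc1cc(/C=C/C(=O)c2cccc(N)c2)ccc1O`), which has hydrogen in place of (furan-2-yl)carbonyl on a nitrogen on an aromatic ring.

Within the data shown here, one measured step bears on this change, and only indirectly. It is a 1.3-fold lower number from compound 1 to compound 2 (0.11 log units; within the scatter), with furan-2-yl in place of thiophen-2-yl on a carbonyl carbon. That step keeps the carbonyl and swaps only the ring, whereas the new change removes both. Among the measured compounds shown here, no measured compound lacks the whole group, so the data give no direct size for its loss. A modest move toward a higher number is a loose expectation, and the opposite direction is not excluded. The expected step is a 1.9-fold higher number from compound 2 to compound 3 (0.29 log units; within the scatter). For compound 3 the estimated value is 6 ug/mL, with an expected range from 2 ug/mL to 20 ug/mL.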

Compound 3, half-maximal inhibitory concentration: 6.02 ug/mL
Compound 3: middle estimate off by 1.0-fold (0.00 log units), on the low side, and the stated range covers the measured number.
By their numbers in this assay, from the lowest: compounds 2, 1 and 3 (each within the scatter of the next).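

In this assay, taking the whole acyl group off the nitrogen on the aromatic ring gives a 1.9-fold higher number from compound 2 to compound 3 (0.29 log units; within the scatter) for the (furan-2-yl)carbonyl and a 1.5-fold higher number from compound 1 to compound 3 (0.18 log units; within the scatter) for the (thiophen-2-yl)carbonyl. The earlier pair varied only the ring and kept the carbonyl, whereas these steps remove ring and carbonyl together, and neither step separates the free amino compound 3 from the amide it is compared with. Among these three compounds, then, the amide on this nitrogen is not shown to be needed for a number in this region, and no measurement available here bears on why the change is so small.

Still open, as far as these compounds go, is whether any group on this nitrogen moves the number beyond the scatter: an acetyl, a benzoyl, a longer chain such as hexanoyl, or a methanesulfonyl in place of the carbonyl. From the compounds shown here alone, it is equally open whether a plain methyl on the amino nitrogen, with no carbonyl at all, would read like compound 3 or like the two amides.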